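The source may hold more compounds than are shown below. What is called first, only, known or untested is meant among the compounds shown, and "the series" means these compounds.

Compound 2, `COc1cc(Cl)cc(-c2nn(-c3cccc(NC(=O)Nc4ccc(Cl)c(C(F)(F)F)c4)c3)cc2-c2ccncc2)c1`, gives the lowest number of the three compounds measured in a functional assay on OVCAR-3 cells (Homo sapiens) for inhibition, read by sulforhodamine B assay, with a stated time of 48 h, tested at 10 uM (a lower number here means a stronger effect, a higher number a weaker effect of the compound at the concentration tested), namely -22.6%. Compound 1, `COc1cc(Cl)cc(-c2nn(-c3cccc(NC(=O)Nc4cccc(C(F)(F)F)c4)c3)cc2-c2ccncc2)c1`, gives -0.41% in this assay, and compound 3, `COc1cc(Cl)cc(-c2nn(-c3cccc(NC(=O)c4cc(C(F)(F)F)cc(C(F)(F)F)c4)c3)cc2-c2ccncc2)c1`, gives 25.5%.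

Compound 4, `COc1cc(Cl)cc(-c2nn(-c3cccc(NC(=O)c4ccc(Cl)c(Cl)c4)c3)cc2-c2ccncc2)c1`, has not yet been measured. Its structure differs from that of compound 2 in one place: 3,4-dichlorophenyl in place of (4-chloro-3-(trifluoromethyl)phenyl)amino on a carbonyl carbon. The urea of compound 2 thus becomes an amide, with a dichlorophenyl ring directly on the carbonyl carbon.

Among the measured compounds shown here, only one measured step concerns a single change, and it is a number 22.2 percentage points lower from compound 1 to compound 2 (beyond the scatter). That step touches the ring that leaves here, so it does not tell how the new ring will behave. For the measured compounds named here, compound 3 is the only measured compound that also carries an aryl group directly on the carbonyl carbon, and its number in this assay is well above that of compound 2, though compound 3 differs from compound 2 in more than one place, so no single step can be drawn from the pair.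

On that basis a rise in number is expected, and the expected step is a number 34.6 percentage points higher from compound 2 to compound 4 (beyond the scatter). Compound 4 is therefore estimated at 12%, with a range from -12% to 36%.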

Compound 4, a percentage reported as activity, at one concentration (the size of the read-out at that concentration, not a potency): 53.4%
Beside the measured number, compound 4's estimate is 41.4 percentage points below it; measured number outside the range, above it.
By their numbers in this assay, from the lowest: compound 2; then compound 1; then compound 3; then compound 4.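

Putting 3,4-dichlorophenyl in place of (4-chloro-3-(trifluoromethyl)phenyl)amino on the carbonyl carbon gives, in this assay, a number 76 percentage points higher from compound 2 to compound 4 (beyond the scatter), so the effect at the tested concentration becomes much weaker. The same kind of swap starting from (3-(trifluoromethyl)phenyl)amino gives a number 53.8 percentage points higher from compound 1 to compound 4 (beyond the scatter), so the direction holds for both ureas shown, and these are the first single-place comparisons to replace the whole group on this carbonyl carbon rather than add a substituent to the outer ring. Nothing available explains why the number rises so far at this position.

The change removes the amino nitrogen with its hydrogen-bond donor and alters the substituents on the ring at the same time, so the compounds shown cannot separate these two parts of the step. A urea carrying (3,4-dichlorophenyl)amino on the same carbonyl carbon would isolate the ring substituents, while a saturated amine such as piperidine in that place would show whether an aromatic ring is needed there at all.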